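Swapping a Methoxy for a Methyl on an Aryl Ring

The source may hold more compounds than are shown below. What is called first, only, known or untested is meant among the compounds shown, and "the series" means these compounds.

Of the compounds shown here, three built on one shared core have been measured in a functional assay (muscle tissue) with Cavia porcellus as the target; a higher number here means that more compound is needed for the effect, a lower number that less compound is needed. Compound 1 `COC(=O)C1=C(C)N=C(C)/C(=C(\O)OC)C1c1ccccc1OC` gives 57.5 nM. Compound 2 `COC(=O)C1=C(C)N=C(C)/C(=C(\O)OC)C1c1cc([N+](=O)[O-])ccc1Cl` gives 30.2 nM, and compound 3 `COC(=O)C1=C(C)N=C(C)/C(=C(\O)OC)C1c1cccc([N+](=O)[O-])c1` gives 3.98 nM. Compound 1 thus stands highest of the three numbers, but its gap to compound 2 lies within the usual scatter, so the two cannot be ranked; only compound 3 sits clearly below it. Among the compounds with values here, the single one-place step among the measured compounds is a 7.6-fold lower number from compound 2 to compound 3 (0.88 log units; beyond the scatter), and that step concerns a chloro group, not the group altered here.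

Compound 4 `COC(=O)C1=C(C)N=C(C)/C(=C(\O)OC)C1c1ccccc1C` differs from compound 1 by methyl in place of methoxy on an aromatic carbon. Within the data shown here, no measured pair shows this particular exchange, so the data offer no direct guide to its size or direction. Without such a guide, the expectation for compound 4 is a number close to that of compound 1, with no step beyond the scatter in either direction, and with a wide range to reflect the missing precedent. Compound 4 is therefore expected to give about 45 nM, within a range from 15 nM to 150 nM. This corresponds to an expected 1.3-fold lower number from compound 1 to compound 4 (0.11 log units; within the scatter).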

Compound 4, half-maximal effective concentration: 6.03 nM
For compound 4 the middle estimate is 7.5-fold (0.87 log units) above the measured one; measured number outside the range, below it.
By their numbers in this assay, from the lowest: compounds 3 and 4 (each within the scatter of the next); then compounds 2 and 1 (each within the scatter of the next).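

In this assay, replacing 2-methoxyphenyl with 2-methylphenyl gives a 9.5-fold lower number from compound 1 to compound 4 (0.98 log units; beyond the scatter), so the group on this aromatic carbon, ortho to a large group, clearly matters; the earlier step concerned a chloro group, not this place. The methoxy that leaves has two heavy atoms and one hydrogen-bond acceptor, while the methyl that enters has one heavy atom and no acceptor, so in this pair a low number does not depend on that acceptor being present. Nothing available explains the size or direction of this step, which therefore stands as an observation only.

As far as these compounds go, it remains open whether an ethyl chain, a fluoro group or an amine on this same carbon would give a number close to that of compound 4 or close to that of compound 1. Also open, from the compounds shown here alone, is whether the exchange of methoxy for methyl would give a step of similar size on an aromatic ring that also carries a nitro group.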